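The compounds below may be only part of what the source reports. "The series", "measured", "known", "first", "only" and "open" are said of these compounds alone.

Among the compounds with values here, the three compounds measured so far share one core and differ only in the group attached to it at one aromatic carbon. Compound 1 `O=C(Nc1ccc(F)c(-c2nc3ncc(-c4cccc(F)c4)cc3[nH]2)c1)N1CCCC1` carries a 3-fluorophenyl there, and in an ADME assay on the whole organism (Mus musculus, strain Swiss Webster) for pharmacokinetics, read by LC-MS, at a dose of 50 mg/kg by the oral route (on this read-out lower numbers stand for lower exposure and higher numbers for higher exposure at the dose given), compound 1 gives 15000 ng.h/mL. Compound 2 `O=C(Nc1ccc(F)c(-c2nc3ncc(-c4ccccc4F)cc3[nH]2)c1)N1CCCC1` carries a 2-fluorophenyl, and in this assay compound 2 gives 4870 ng.h/mL. Compound 3 `O=C(Nc1ccc(F)c(-c2nc3ncc(-c4ccc(F)c(F)c4)cc3[nH]2)c1)N1CCCC1` carries a 3,4-difluorophenyl, and in this assay compound 3 gives 12000 ng.h/mL. Among these, compound 3 stands second highest: its nearest neighbour is compound 1, since a 1.3-fold lower number from compound 1 to compound 3 (0.10 log units; within the scatter), and its furthest is compound 2, since a 2.5-fold higher number from compound 2 to compound 3 (0.39 log units; beyond the scatter). Changing where the fluorine sits on the phenyl ring gave at most a modest shift: a 3.1-fold lower number from compound 1 to compound 2 (0.49 log units; beyond the scatter).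

Compound 4 `O=C(Nc1ccc(F)c(-c2nc3ncc(C(F)(F)F)cc3[nH]2)c1)N1CCCC1` makes a different kind of change: trifluoromethyl in place of 3,4-difluorophenyl on an aromatic carbon. Within the data shown here, none of the measured steps removes the phenyl ring altogether, so the three steps are only an indirect guide; they show that changes at this position have so far shifted exposure by no more than modest amounts. Compound 4 is therefore expected to land near compound 3, with a 1.2-fold lower number from compound 3 to compound 4 (0.08 log units; within the scatter) expected to stay within or only just beyond the scatter. The estimate for compound 4 is 10000 ng.h/mL, with a range from 3000 ng.h/mL to 30000 ng.h/mL.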

Compound 4, area under the concentration-time curve: 489 ng.h/mL
Beside the measured number, compound 4's estimate is 20-fold (1.31 log units) above it; the whole stated range lies above it.
By their numbers in this assay, from the lowest: compound 4; then compound 2; then compounds 3 and 1 (each within the scatter of the next).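

In this assay, within the data shown here, this position proved far less forgiving than the earlier compounds suggested. Moving or adding fluorine on the phenyl ring had shifted exposure only modestly, but replacing the whole ring with trifluoromethyl has a much larger effect on the number, both for the 3,4-difluorophenyl (a 25-fold lower number from compound 3 to compound 4 (1.39 log units; beyond the scatter)) and for the 3-fluorophenyl (a 31-fold lower number from compound 1 to compound 4 (1.49 log units; beyond the scatter)), while the step from the 2-fluorophenyl is smaller but still clear (a 10-fold lower number from compound 2 to compound 4 (1.00 log units; beyond the scatter)). Across these four compounds, then, whether a six-membered aromatic ring of carbon only stands at this position matters more than where its fluorines sit, and none of the four goes against this, since even compound 2, the lowest of the three with a ring, stays well above compound 4.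

The compounds shown leave open whether the ring itself is needed, as a pyridine ring, a saturated cyclohexyl ring, a plain methyl, a longer chain such as butyl or an amine at this carbon could each separate the ring from the trifluoromethyl group. Nothing given here explains why exposure falls so steeply with this change.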